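Removing a ring benzyl from a weak cell-growth inhibitor

A few compounds are considered here, and "the series" means these few. Any claim that something is new, unique, unknown or untested is made for them only; others in the source may bear on it.

Measured compounds:
compound 1, `COC(=O)C[C@H](NC(=O)OC(C)(C)C)C(=O)N(Cc1ccccc1)C1(C(=O)NCc2ccccc2)CCN(Cc2ccccc2)CC1`, 19000 nM in a functional assay on CCRF-CEM cells (Homo sapiens) for inhibition, with a stated time of 72 h; a lower number here means a stronger inhibitor, a higher number a weaker inhibitor
compound 2, `COC(=O)C[C@H](NC(=O)OC(C)(C)C)C(=O)N(Cc1ccccc1)C1(C(=O)NCc2ccccc2)CCNCC1`, 124000 nM in this assay
compound 3, `CCC(C)N(C(=O)[C@@H](N)CC(=O)OC)C1(C(=O)NCc2ccccc2)CCN(Cc2ccccc2)CC1`, 238000 nM in this assay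

Compound 1 and compound 2 share a core and differ only by hydrogen in place of benzyl on an amine nitrogen in a ring; this change produced a 6.5-fold higher number from compound 1 to compound 2 (0.81 log units; beyond the scatter). Compound 3 stands with compound 2 within the scatter, while compound 1 gives the lowest of the three numbers. The difference between the core of compound 1 and the core of compound 3 is not broken down here. Compound 4, `CCC(C)N(C(=O)[C@@H](N)CC(=O)OC)C1(C(=O)NCc2ccccc2)CCNCC1`, is not yet measured; it differs from compound 3 by hydrogen in place of benzyl on an amine nitrogen in a ring, the same change, at the same place, as that from compound 1 to compound 2. Because a 6.5-fold higher number from compound 1 to compound 2 (0.81 log units; beyond the scatter) weakened inhibition, compound 4 is expected to follow with a step of about a 4.2-fold higher number from compound 3 to compound 4 (0.62 log units; beyond the scatter) in this assay. Compound 4 is therefore estimated at 1000000 nM, between 300000 nM and 3000000 nM, although at such weakness this assay may report only a limit.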

Compound 4, half-maximal inhibitory concentration: > 250000 nM
Compound 4: a limit, no number; the forecaster's own chance of this, stated with the estimate: 50%; the middle value does not contradict the limit.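

In this assay compound 4 gives > 250000 nM, which is a limit of the assay and not a number. Hydrogen in place of benzyl on the amine nitrogen in the ring therefore gives only a floor on the second core, an at least 1.0-fold higher number from compound 3 to compound 4 (0.02 log units; that floor lies within the scatter), so the result is compatible with the change carrying over but does not confirm it: the same change on two cores in this assay, a 6.5-fold higher number (0.81 log units; beyond the scatter) from compound 1 to compound 2 and an at least 1.0-fold higher number (0.02 log units; that floor lies within the scatter) from compound 3 to compound 4; the limit leaves it open whether they differ. Whether the step has the same size on both cores remains unsettled.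

The compounds shown leave open whether a methyl or an acetyl on this amine nitrogen would behave more like benzyl or like hydrogen. They also leave open how a carboxylic acid in place of the methyl ester would read.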